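The source may report more compounds than this note shows. Statements on the series, on what has been measured and on what is new or still open speak of the compounds shown alone.

Measured compounds:
compound 1, `CCCCSc1nc(N)nc2c1ncn2/C=C1/CC1(CO)CO`: > 300000 nM
compound 2, `Nc1nc(NCc2ccccc2)c2ncn(/C=C3/CC3(CO)CO)c2n1`: > 300000 nM
compound 3, `CN(C)c1nc(N)nc2c1ncn2/C=C1/CC1(CO)CO`: > 300000 nM

In an ADME assay on HFF cells (Homo sapiens) for cytotoxicity, with a stated time of 8 days (a higher number here means that more compound is tolerated, a lower number that less compound is tolerated), compound 1 gives > 300000 nM, and this value is a limit of the assay rather than a number. Compound 2 also gives > 300000 nM, again a limit. Compound 3 gives > 300000 nM, once more a limit. All three values therefore sit at the limit of > 300000 nM in this assay, at which 3 of the 3 values shown sit, and none of the three steps among them can be read: a step that the two limits leave unreadable from compound 1 to compound 2, a step that the two limits leave unreadable from compound 1 to compound 3 and a step that the two limits leave unreadable from compound 2 to compound 3.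

The compound still to be measured is compound 4, `CCOc1nc(N)nc2c1ncn2/C=C1/CC1(CO)CO`. It differs from compound 1 by ethoxy in place of butylsulfanyl on an aromatic carbon. The three measured steps bear on this change only in that each of them exchanges the group on the same aromatic carbon and each ends at the same limit. Among the measured compounds shown here, no direction and no size of step can be drawn from them, so no step beyond the scatter is expected in this assay from compound 1 to compound 4.

Compound 4 is therefore expected to give about 300000 nM, within 100000 nM to 300000 nM. The step this estimate implies is a number no higher from compound 1 to compound 4 (the limit leaves the size open), and a limit rather than a number is the most likely outcome.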

Compound 4, half-maximal cytotoxic concentration: > 300000 nM
Compound 4 gave a limit, no number; the forecaster's own chance of this, stated with the estimate: 85%; the middle value sits exactly at the limit.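

In this assay compound 4 gives > 300000 nM and this value is a limit. No step between compound 4 and compound 1, compound 2 or compound 3 can be read, as all four values are limits: the limit of > 300000 nM in this assay, at which 4 of the 4 values shown sit.

The compounds shown leave open at what concentration any of them becomes cytotoxic to these cells, and whether the group on this aromatic carbon alters that concentration.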